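The source may report more compounds than this note shows. Statements on the series, on what has been measured and on what is new or still open speak of the compounds shown alone.

Working notes on the series.

Going by the values given here, compound 1 `CS(=O)(=O)c1nn(Cc2nc3cc(Cl)ccc3n2CCCCO)c2cnccc12` stands lowest of the two numbers so far in an ADME assay on the whole organism (strain ICR) for pharmacokinetics, with Mus musculus as the target, at a dose of 2 mg/kg by the intravenous route (a lower number here means that more of the compound stays in the plasma, a higher number that more of the compound sits outside the plasma), where compound 1 gives 1.08 L/kg. Its nearest neighbour is compound 2 `CC(C)(O)CCCn1c(Cn2nc(S(C)(=O)=O)c3ccncc32)nc2cc(Cl)ccc21`, which in this assay gives 1.09 L/kg; the step of a 1.0-fold higher number from compound 1 to compound 2 (0.00 log units; within the scatter) sits within the scatter, so the two share one level.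

The next compound, compound 3 `CS(=O)(=O)c1nn(Cc2nc3cc(Cl)ccc3n2CCC(F)(F)F)c2cnccc12`, differs from compound 1 in one place: trifluoromethyl in place of 2-hydroxyethyl on a saturated chain carbon, two bonds along the chain from an aromatic nitrogen. Among the compounds with values here, the only measured step, from compound 1 to compound 2, kept a hydroxyl on the chain while adding two methyl groups and moved the number not at all. It therefore bears only loosely on the present change, in which the group entering carries no hydrogen-bond donor and no hydrogen-bond acceptor where the leaving group carried one of each. Within the data shown here, no measured pair shows what that loss does in this assay.

The expectation for compound 3 is a small rise in this assay, a 1.3-fold higher number from compound 1 to compound 3 (0.11 log units; within the scatter), possibly within the scatter. Compound 3 is estimated at 1.4 L/kg, within a range from 0.8 L/kg to 2.5 L/kg.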

Compound 3, volume of distribution at steady state: 1.04 L/kg
Estimate against measurement, compound 3: 1.3-fold (0.13 log units) above; measured number inside the range.
By their numbers in this assay, from the lowest: compounds 3, 1 and 2 (each within the scatter of the next).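

In this assay, the change at this position removes the hydrogen-bond donor and acceptor of 2-hydroxyethyl, and trifluoromethyl enters with neither, yet the result is a 1.0-fold lower number from compound 1 to compound 3 (0.02 log units; within the scatter). The earlier step kept a hydroxyl on the chain throughout, whereas here the comparison with the branched hydroxylated chain reads the same, a 1.0-fold lower number from compound 2 to compound 3 (0.02 log units; within the scatter), so compound 1, compound 2 and compound 3 share one level and a hydroxyl on this chain is not required to hold it. No measurement at hand accounts for this shared level.

The compounds shown leave open whether the same level would hold with an amine or a carboxylic acid at the end of this chain, or with a longer chain carrying trifluoromethyl. They also leave open whether a change on the shared core, rather than on the chain, would move the number in this assay.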